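The compounds below may be only part of what the source reports. "The series", "measured", "known", "first", "only" and "open" are said of these compounds alone.

Values in an ADME assay on Vero cells (Chlorocebus sabaeus) for cytotoxicity, read by resazurin assay, with a stated time of 72 h (on this read-out higher numbers stand for weaker inhibition and lower numbers for stronger inhibition), so far
- compound 1 `Cc1ccc(C(=O)CCN2CCN(c3ccc(F)cc3)CC2)cc1` gives 55400 nM
- compound 2 `O=C(CCN1CCN(c2ccc(F)cc2)CC1)c1ccc(Br)cc1` gives 99500 nM
- compound 3 `O=C(CCN1CCN(c2ccc(F)cc2)CC1)c1ccc(C(F)(F)F)cc1` gives 28500 nM

Compound 3 is set apart from the bromo compound (a 3.5-fold lower number from compound 2 to compound 3 (0.54 log units; beyond the scatter)) but not from the methyl compound (a 1.9-fold lower number from compound 1 to compound 3 (0.29 log units; within the scatter)). The next change leads to compound 4 `O=C(CCN1CCN(c2ccc(F)cc2)CC1)c1ccc(OC(F)(F)F)cc1`, with trifluoromethoxy in place of trifluoromethyl on an aromatic carbon, para to a large group (trifluoromethoxy in place of trifluoromethyl on an aromatic carbon).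

All the measured variation sits at this same place. The remaining step there (a 1.8-fold higher number from compound 1 to compound 2 (0.25 log units; within the scatter)) also stays within the scatter, and the largest step seen is the modest one from bromo to trifluoromethyl. For the measured compounds named here, no measured compound carries a trifluoromethoxy group, so these steps suggest a likely size but no firm direction.

Taking compound 3 (28500 nM) as the nearest reference, no step beyond the scatter is expected in this assay. The expected step is small (a 1.2-fold higher number from compound 3 to compound 4 (0.09 log units; within the scatter)) and its direction is uncertain. Compound 4 is estimated at 35000 nM in this read-out, with 15000 nM and 80000 nM as the expected ends of the range.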

Compound 4, half-maximal inhibitory concentration: 70300 nM
For compound 4 the middle estimate is 2.0-fold (0.30 log units) below the measured one; the range from low to high includes it.
By their numbers in this assay, from the lowest: compounds 3, 1, 4 and 2 (each within the scatter of the next, the first and the last beyond it).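

In this assay, the position on the aromatic carbon para to a large group responds to a change as small as trifluoromethyl to trifluoromethoxy, which adds one oxygen and one hydrogen-bond acceptor to the group and gives a modest step beyond the scatter (a 2.5-fold higher number from compound 3 to compound 4 (0.39 log units; beyond the scatter)). Compound 4 cannot be separated from either of the other two compounds, with the steps to it from the bromo compound (a 1.4-fold lower number from compound 2 to compound 4 (0.15 log units; within the scatter)) and from the methyl compound (a 1.3-fold higher number from compound 1 to compound 4 (0.10 log units; within the scatter)) both staying within the scatter. Compound 3 now differs beyond the scatter from two of the three other groups at this place, though not from methyl, so the trifluoromethyl compound is only partly set apart and the four compounds do not form a clean ranking.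

Going by these compounds, whether an amine, a hydroxyl or a carboxylic acid on this aromatic carbon would move the number outside the span seen so far stays open, as does any effect of changes to the shared core, which is the same in all four compounds. Nothing available accounts for the step between the two fluorinated groups.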